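This account rests on a few compounds, and the source may have more. Where it says the series, first, only, none or still open, it means among the compounds named here.

Compound 1 `O=C(NC(=S)Nc1cccc(C(F)(F)F)c1)[C@H]1C[C@@H]2CC[C@H]1C2`: 20000 nM
Compound 2 `CC(=O)NC(=S)Nc1cccc(C(F)(F)F)c1`: > 100000 nM

Both compounds were tested in an ADME assay on Vero 76 cells (Chlorocebus sabaeus) for cytotoxicity, read by crystal violet staining, with a stated time of 96 h; a lower number here means that less compound is tolerated, a higher number that more compound is tolerated. Compound 2 reads > 100000 nM, which is a limit of the assay and not a number (the limit of > 100000 nM in this assay, at which 1 of the 2 values shown sits). Compound 3 `FC(F)(F)c1cccc(NC(=S)Nc2ccccc2Br)c1` has 2-bromophenyl in place of acetyl on an amide-type nitrogen. For the measured compounds named here, the only measured step that bears on this is an at least 5.0-fold higher number from compound 1 to compound 2 (0.69 log units; beyond the scatter), although it lies at a different place, on a carbonyl carbon. Read backwards, that step pairs the larger group with the lower number, so a fall of similar size is expected, an at least 3.3-fold lower number from compound 2 to compound 3 (0.52 log units; beyond the scatter). For compound 3 the estimated value is 30000 nM, with an expected range of 10000 nM to 100000 nM.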

Compound 3, half-maximal cytotoxic concentration: 50000 nM
Beside the measured number, compound 3's estimate is 1.7-fold (0.22 log units) below it; measured number inside the range.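

In this assay putting 2-bromophenyl in place of acetyl on the amide-type nitrogen gives an at least 2.0-fold lower number from compound 2 to compound 3 (0.30 log units; that floor lies within the scatter) and so shows no fall beyond the scatter. Unlike the earlier step, which kept the carbonyl, this change removes it and places an aromatic ring on that nitrogen, yet compound 3 gives a measured number. As far as these compounds go, the size of the step stays open because compound 2 stands at a limit of the assay and not at a number: the limit of > 100000 nM in this assay, at which 1 of the 3 values shown sits.

From the compounds shown here alone, whether the bromine matters remains open, as an unsubstituted phenyl or a chlorophenyl could show. So does the effect of a longer chain or an amine on this nitrogen.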